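This account rests on a few compounds, and the source may have more. Where it says the series, first, only, none or still open, it means among the compounds named here.

Compound 1 `CCN(c1nc(Cl)nc(N[C@@H](C)c2ccccc2)n1)C(C)C` gives 537 nM in an ADME assay on the whole organism for inhibition, with Oryza sativa as the target, with a stated time of 4 days (on this read-out higher numbers stand for weaker inhibition and lower numbers for stronger inhibition), the lowest of the three numbers measured. Compound 2 `CCNc1nc(Cl)nc(N[C@H](C)c2ccccc2)n1` gives 14100 nM in this assay, and compound 3 `CCN(CC)c1nc(Cl)nc(N[C@H](C)c2ccccc2)n1` gives 6310 nM. Compound 1 thus stands well apart from both: the value of compound 3 lies a good deal higher, and that of compound 2 higher still.

Compound 4 `CCCCNc1nc(Cl)nc(N[C@@H](C)c2ccccc2)n1` is the next compound to be read in this assay. It differs from compound 1 in one place: butylamino in place of ethyl(isopropyl)amino on an aromatic carbon. Among the measured compounds shown here, the only measured step that touches the same position is a 2.2-fold lower number from compound 2 to compound 3 (0.35 log units; beyond the scatter), a modest gain when a second alkyl group is added on that nitrogen. Compound 4 moves the other way, from a nitrogen carrying two alkyl groups to one carrying a single alkyl group and a hydrogen, so a weakening is the more likely outcome, with the size uncertain since the groups involved differ from those in compounds 2 and 3.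

He estimates that compound 4 will give 3000 nM in this assay, within a range of 800 nM to 12000 nM, which means a step of a 5.6-fold higher number from compound 1 to compound 4 (0.75 log units; beyond the scatter).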

Compound 4, half-maximal inhibitory concentration: 23400 nM
Estimate against measurement, compound 4: 7.8-fold (0.89 log units) below; measured number outside the range, above it.
By their numbers in this assay, from the lowest: compound 1; then compound 3; then compounds 2 and 4 (each within the scatter of the next).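

In this assay, butylamino in place of ethyl(isopropyl)amino on this aromatic carbon gives a 44-fold higher number from compound 1 to compound 4 (1.64 log units; beyond the scatter), a large step that shows this position can matter far more than the modest 2.2-fold lower number from compound 2 to compound 3 (0.35 log units; beyond the scatter) suggested. Both steps point the same way: in each of these two pairs, the compound with a hydrogen on the nitrogen has the higher number, and neither pair goes against this. No measurement offered here accounts for the size of the new step.

The change from compound 1 to compound 4 alters the alkyl groups and adds the hydrogen on the nitrogen together, so the compounds shown leave open how much of the step belongs to each. On these data alone, how butyl(ethyl)amino or a morpholine ring joined through its nitrogen would read at this position also remains open.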